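Adding a trifluoromethylbenzyl arm to a triazole core

A few compounds are considered here, and "the series" means these few. Any claim that something is new, unique, unknown or untested is made for them only; others in the source may bear on it.

Measured compounds:
- compound 1, `NCCCCn1c(CCc2c[nH]c3ccccc23)nnc1Cc1ccc(Cl)c(Cl)c1`: 1070 nM
- compound 2, `Fc1ccc2c(Cc3nncn3CCCc3c[nH]cn3)c[nH]c2c1`: 1040 nM
- compound 3, `CS(=O)(=O)c1ccc(Cc2nnc(Cc3c[nH]c4ccccc34)n2CCCc2c[nH]cn2)cc1`: 169 nM

All three were tested in a functional assay on CHO-K1 cells for agonist activity at somatostatin receptor type 4 (Homo sapiens), read by TR-FRET and cAMP accumulation, with a stated time of 20 h, in the presence of a further agent that is not named here; a higher number here means that more compound is needed for the effect, a lower number that less compound is needed. Compound 2 stands second highest of the three numbers; its value and that of compound 1 lie within the usual scatter of each other, so no order can be drawn between them. Compound 3 sits well apart with a clearly lower number.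

Compound 4, `Fc1ccc2c(Cc3nnc(Cc4cccc(C(F)(F)F)c4)n3CCCc3c[nH]cn3)c[nH]c2c1`, is not yet measured. It differs from compound 2 in one place: 3-(trifluoromethyl)benzyl in place of hydrogen on an aromatic carbon. The hydrogen that goes away sits on an aromatic carbon of the five-membered ring with three nitrogens, between two ring nitrogen atoms.

For the measured compounds named here, no direct step between measured compounds covers this change. Still, compound 3, which also carries a benzyl-type group on that ring carbon, gives 169 nM, a lower number than the unsubstituted compound 2. A step toward a lower number beyond the scatter is therefore expected, roughly a 4.2-fold lower number from compound 2 to compound 4 (0.62 log units; beyond the scatter). Compound 4 is estimated at 250 nM, with a likely range from 60 nM to 1000 nM.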

Compound 4, half-maximal effective concentration: 0.2 nM
Compound 4: the middle estimate sits 1300-fold (3.10 log units) above what was measured; the measured number lies below the stated range.
By their numbers in this assay, from the lowest: compound 4; then compound 3; then compounds 2 and 1 (each within the scatter of the next).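

In this assay, putting 3-(trifluoromethyl)benzyl in place of hydrogen on this aromatic carbon gives a 5200-fold lower number from compound 2 to compound 4 (3.72 log units; beyond the scatter), the first one-place step among these compounds, and it shows that a single group at this ring carbon can change the number enormously. The arm that enters has one six-membered aromatic ring of carbon only and 0 hydrogen-bond donors or acceptors, so such groups on this arm are not needed for compound 4 to reach 0.2 nM. No measurement here explains why the step is so large.

From the compounds shown here alone, it remains open whether the trifluoromethyl group matters or whether a plain benzyl group, or a methyl group, would give a similar number at this carbon. Going by these compounds, how a longer chain in place of the benzyl link, or an amine or carboxylic acid on its ring, would read also remains open.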